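Aryl-triazole esters on the shared core: expectation for compound 4

A few compounds are considered here, and "the series" means these few. Any claim that something is new, unique, unknown or untested is made for them only; others in the source may bear on it.

Compound 1 `C#CCOC(=O)/C(C)=C/CC/C(C)=C/CC/C(C)=C/CC[C@@H]1[C@@]2(C)CCC(=O)C(C)(C)[C@H]2CC[C@@]1(C)O` carries an ethynyl on the ester chain carbon; in a functional assay on DU-145 cells (Homo sapiens) for antiproliferative activity, read by MTT assay, with a stated time of 48 h (on this read-out lower numbers stand for stronger inhibition and higher numbers for weaker inhibition), compound 1 gives 46100 nM. Compound 3 `C/C(=C\CC/C(C)=C/CC[C@@H]1[C@@]2(C)CCC(=O)C(C)(C)[C@H]2CC[C@@]1(C)O)CC/C=C(\C)C(=O)OCc1cn(-c2ccc(C)cc2)nn1` bears a 1-(4-methylphenyl)-1H-1,2,3-triazol-4-yl instead. In this assay compound 3 reaches only a limit, > 150000 nM. Compound 2 `C/C(=C\CC/C(C)=C/CC[C@@H]1[C@@]2(C)CCC(=O)C(C)(C)[C@H]2CC[C@@]1(C)O)CC/C=C(\C)C(=O)OCc1cn(-c2ccccc2[N+](=O)[O-])nn1` is the 2-nitrophenyl analogue. In this assay compound 2 also gives only a limit, > 150000 nM. The step of an at least 3.2-fold higher number from compound 1 to compound 3 (0.51 log units; beyond the scatter) is thus the only readable one, while a step that the two limits leave unreadable from compound 2 to compound 3 remains unreadable since both sit at the limit of > 150000 nM in this assay, at which 2 of the 3 values shown sit. Compound 4 `C/C(=C\CC/C(C)=C/CC[C@@H]1[C@@]2(C)CCC(=O)C(C)(C)[C@H]2CC[C@@]1(C)O)CC/C=C(\C)C(=O)OCc1cn(-c2ccccc2Br)nn1` differs from compound 3 by 2-bromophenyl in place of 4-methylphenyl on an aromatic nitrogen. Both aryl-triazole analogues sit at the limit, so for compound 4 the expected step that the limit leaves unreadable from compound 3 to compound 4 is none beyond the scatter. Compound 4 is estimated at 200000 nM, range 100000 nM to 500000 nM.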

Compound 4, half-maximal inhibitory concentration: > 150000 nM
Compound 4: only a limit was reported (the forecaster's own chance of this, stated with the estimate: 80%); the middle value is on the limit's open side.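

Compound 4 adds a third aryl-triazole ester at the same limit in this assay: the limit of > 150000 nM in this assay, at which 3 of the 4 values shown sit. With an at least 3.2-fold higher number from compound 1 to compound 4 (0.51 log units; beyond the scatter), the loss against the ethynyl ester seen with 4-methylphenyl also holds for 2-bromophenyl. The steps among compound 2, compound 3 and compound 4 cannot be read, so nothing separates these aryl groups.

On these data alone, it remains open whether an amine or a carboxylic acid on the phenyl ring would give a measurable number in this assay. Also open, as far as these compounds go, is whether a triazole carrying a simple methyl instead of an aryl group would stay closer to compound 1.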